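This account rests on a few compounds, and the source may have more. Where it says the series, first, only, none or still open, it means among the compounds named here.

Measured in a functional assay on MCF7 cells (Homo sapiens) for antiproliferative activity; a higher number here means a weaker inhibitor, a lower number a stronger inhibitor:
- compound 1 `Cc1ccc(C(=O)Nc2ccc(O)c3c(=O)cc(-c4ccccc4Cl)oc23)cc1`: 10000 nM
- compound 2 `O=C(Nc1c(O)cc(O)c2c(=O)cc(-c3ccccc3Cl)oc12)c1ccccc1`: 8500 nM
- compound 3 `O=C(Nc1c(O)cc(O)c2c(=O)cc(-c3ccccc3Cl)oc12)c1ccc(Cl)cc1`: 13000 nM

Compound 3, at 13000 nM, lies within the scatter of both other compounds, so no order can be read among the three. Compound 4 `Cc1ccc(C(=O)Nc2c(O)cc(O)c3c(=O)cc(-c4ccccc4Cl)oc23)cc1` carries methyl in place of chloro on an aromatic carbon, para to a large group: methyl in place of chloro on an aromatic carbon. Among the compounds with values here, the one measured step at this place is a 1.5-fold higher number from compound 2 to compound 3 (0.18 log units; within the scatter), chloro in place of hydrogen, and it stays within the scatter. Compound 1 has the 4-methylphenyl group on a different core and gives 10000 nM. No change beyond the scatter is therefore expected, and the estimated step is a 1.3-fold lower number from compound 3 to compound 4 (0.11 log units; within the scatter). In this assay the expected value for compound 4 is 10000 nM, with an estimated range of 5000 nM to 20000 nM.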

Compound 4, half-maximal inhibitory concentration: 9700 nM
The estimate for compound 4 lay 1.0-fold (0.01 log units) above the measured number, and the stated range covers the measured number.
By their numbers in this assay, from the lowest: compounds 2, 4, 1 and 3 (each within the scatter of the next).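

In this assay, methyl at this place, on the 4-methylphenyl group, gives no change beyond the scatter, whether it replaces chloro (a 1.3-fold lower number from compound 3 to compound 4 (0.13 log units; within the scatter)) or hydrogen (a 1.1-fold higher number from compound 2 to compound 4 (0.06 log units; within the scatter)). The added hydroxy on the core also stays within the scatter (a 1.0-fold lower number from compound 1 to compound 4 (0.01 log units; within the scatter)), so neither place yet shows any effect on the number. Nothing available bears on a cause for these steps.

Within the data shown here, every step so far lies within the scatter, so it remains open whether this position responds to any substituent. An amine, a carboxylic acid or a longer chain in place of methyl could test this.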